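Oxazole ketones: pyridyl replaces the acyl group

The source may hold more compounds than are shown below. What is called first, only, known or untested is meant among the compounds shown, and "the series" means these compounds.

Going by the values given here, compound 1 `CC(C)(C)C(=O)c1coc(C(=O)CCCCCCc2ccccc2)n1` is the one member of the series with a numerical result. In an assay on HEK-293T cells for inhibition of diacylglycerol lipase-alpha (Homo sapiens), read by colorimetric assay (on this read-out higher numbers stand for weaker inhibition and lower numbers for stronger inhibition), compound 1 gives 479 nM. Among the compounds with values here, compound 2 `CC(=O)c1cnc(C(=O)CCCCCCc2ccccc2)o1` is the only other compound with a result so far. In this assay compound 2 returns a limit rather than a number, > 10000 nM. Within the data shown here, compound 1 therefore stands as the sole number in the set, while the other entry sits at the limit of > 10000 nM in this assay, at which 1 of the 2 values shown sits; no step between two measured compounds is available, so the size of any single change has not yet been calibrated.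

Compound 3 `O=C(CCCCCCc1ccccc1)c1nc(-c2ccccn2)co1` is still to be measured. Relative to compound 1 the difference is pyridin-2-yl in place of (tert-butyl)carbonyl on an aromatic carbon. A group with no ring and one double bond outside aromatic rings leaves, and one six-membered aromatic ring with 1 hetero atom enters on the same aromatic carbon of the shared core.

With nothing measured to lean on, a step from compound 1 to compound 3 of a 2.4-fold lower number from compound 1 to compound 3 (0.38 log units; beyond the scatter) is expected, in the direction of stronger inhibition and of a size only modestly beyond the scatter. Compound 3 is accordingly estimated at 200 nM, within a range of 30 nM to 2000 nM.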

Compound 3, half-maximal inhibitory concentration: > 10000 nM
Compound 3 was reported as a limit; the forecaster's own chance of this, stated with the estimate: 10%; at least 50-fold (1.69 log units) between middle value and limit.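

In this assay, going by these compounds alone, pyridin-2-yl in place of (tert-butyl)carbonyl on this aromatic carbon gives the one step so far, an at least 20-fold higher number from compound 1 to compound 3 (1.31 log units; beyond the scatter), which shows that the position is not indifferent to the group it carries. The group that leaves and the group that enters have the same count of heavy atoms and of hydrogen-bond acceptors, so matching these counts at this carbon is not enough to keep the inhibition seen with compound 1. Compound 3 joins the entries that sit at a limit rather than at a number: the limit of > 10000 nM in this assay, at which 2 of the 3 values shown sit.

The compounds shown leave open whether the loss goes with removing the carbonyl or with bringing in the pyridine ring, and a plain phenyl ring or a cyclohexylcarbonyl group on the same carbon would separate the two. Also open, going by these compounds, is whether any group on this carbon gives a lower number than compound 1, with a smaller ketone such as cyclopropylcarbonyl or a carboxylic acid ester as candidates.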